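The source may hold more compounds than are shown below. What is called first, only, known or untested is meant among the compounds shown, and "the series" means these compounds.

Measured in a functional assay on HCT-116 cells (Homo sapiens) for inhibition, read by colorimetric assay, with a stated time of 3 days; a higher number here means a weaker inhibitor, a lower number a stronger inhibitor:
- compound 1 `O=C(CCCCCCNC(=O)C(O)(O)C(F)(F)F)Nc1ccccc1Br`: 14500 nM
- compound 2 `COc1ccc(NC(=O)CCCCCCNC(=O)C(O)(O)C(F)(F)F)cc1`: 4520 nM
- compound 3 `O=C(CCCCCCNC(=O)C(O)(O)C(F)(F)F)Nc1ccccc1`: 9140 nM

Compound 3 cannot be separated from compound 1, a 1.6-fold lower number from compound 1 to compound 3 (0.20 log units; within the scatter). Compound 2 stands clear of it, a 2.0-fold higher number from compound 2 to compound 3 (0.31 log units; beyond the scatter), so compound 3 lies on the higher-number side of this small set.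

The next compound is compound 4 `COc1ccccc1NC(=O)CCCCCCNC(=O)C(O)(O)C(F)(F)F`. The change is methoxy in place of hydrogen on an aromatic carbon, ortho to a large group.

Within the data shown here, two measured steps bear on this. Among the measured compounds shown here, the only step involving methoxy is a 2.0-fold higher number from compound 2 to compound 3 (0.31 log units; beyond the scatter), which is modest, and read in reverse it points to a lower number when methoxy enters. For the measured compounds named here, that methoxy, however, sits on a different ring carbon from the one in compound 4. Going by the values given here, the only measured change at the carbon concerned is a 1.6-fold lower number from compound 1 to compound 3 (0.20 log units; within the scatter), which involves bromo rather than methoxy and stays within the scatter.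

In this assay, a small step is therefore expected, most likely none beyond the scatter, and leaning if anything towards a lower number. The expected change is a 1.2-fold lower number from compound 3 to compound 4 (0.09 log units; within the scatter). For compound 4 the estimated value is 7500 nM, with an expected range of 3500 nM to 16000 nM.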

Compound 4, half-maximal inhibitory concentration: 10100 nM
Compound 4: the middle estimate sits 1.3-fold (0.13 log units) below what was measured, and the stated range covers the measured number.
By their numbers in this assay, from the lowest: compound 2; then compounds 3, 4 and 1 (each within the scatter of the next).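

In this assay the aromatic carbon ortho to a large group tolerates exchange without a readable change: methoxy in place of hydrogen gives (a 1.1-fold higher number from compound 3 to compound 4 (0.04 log units; within the scatter)) and methoxy in place of bromo gives (a 1.4-fold lower number from compound 1 to compound 4 (0.16 log units; within the scatter)), so hydrogen, bromo and methoxy cannot be separated at this carbon in the compounds shown. Among these compounds, the methoxy group alone therefore does not carry the lower number of compound 2, since 2-methoxyphenyl in place of 4-methoxyphenyl gives a modest step beyond the scatter (a 2.2-fold higher number from compound 2 to compound 4 (0.35 log units; beyond the scatter)), and compound 2 remains the only compound separated from all the others. Nothing available explains this difference between the two methoxy placements.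

Open, going by these compounds, is whether the lower number at the 4-methoxyphenyl placement is particular to methoxy or also appears with other groups on that ring carbon, such as an amine or a carboxylic acid. Also open, on these data alone, is whether the flat reading at the carbon ortho to a large group extends to larger groups there, such as a second phenyl ring, or holds with a shorter or longer chain.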